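The compounds below may be only part of what the source reports. "The series", "measured", "known", "first", "only" and "open" are said of these compounds alone.

The study follows a shared core bearing an amino group and a nitrile, examined in a functional assay on NCI-H2122 cells (Homo sapiens) for inhibition, read by microscopy, with a stated time of 10 days (on this read-out lower numbers stand for stronger inhibition and higher numbers for weaker inhibition), throughout. Compound 1 `Cn1nc(-c2ccccc2)c2c1OC(N)=C(C#N)C2c1ccc(F)cc1` carries a fluoro group on its pendant aryl ring, and in this assay compound 1 reaches only the limit of the assay, > 10000 nM. Compound 2 `Cn1nc(-c2ccccc2)c2c1OC(N)=C(C#N)C2c1ccc(C(F)(F)F)cc1` bears trifluoromethyl in its place; in this assay compound 2 gives 4100 nM. That change, trifluoromethyl in place of fluoro on an aromatic carbon, amounts to an at least 2.4-fold lower number from compound 1 to compound 2 (0.38 log units; beyond the scatter), its starting point being a limit (the limit of > 10000 nM in this assay, at which 1 of the 3 values shown sits). Compound 3 `Cc1nn(C)c2c1C(c1ccc(C#N)cc1)C(C#N)=C(N)O2` gives 5600 nM in this assay; compound 3 thus stands alongside compound 2, the two numbers lying within the scatter of each other.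

Compound 4 `Cn1nc(-c2ccccc2)c2c1OC(N)=C(C#N)C2c1ccc(C#N)cc1` differs from compound 3 by phenyl in place of methyl on an aromatic carbon. Among the measured compounds shown here, no measured step concerns this change: the single measured step, from compound 1 to compound 2, alters the pendant aryl ring at a different place. Compounds 1 and 2 already carry phenyl at the site in question, but neither bears the nitrile of compound 3, so no direct comparison exists. The expectation is therefore no step beyond the scatter, a 1.2-fold lower number from compound 3 to compound 4 (0.09 log units; within the scatter). Compound 4 is estimated at 4500 nM, within a range from 1500 nM to 13000 nM.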

Compound 4, half-maximal inhibitory concentration: 5200 nM
Compound 4: middle estimate off by 1.2-fold (0.06 log units), on the low side; the measured number falls inside the stated range.
By their numbers in this assay, from the lowest: compounds 2, 4 and 3 (each within the scatter of the next). At a limit, above all of these: compound 1.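

Among the compounds shown here, compound 4 supplies the first measured change on the aromatic carbon of the five-membered aromatic ring, and with the cyano-bearing pendant aryl ring held fixed, phenyl in place of methyl does not separate the two compounds in this assay: the result is a 1.1-fold lower number from compound 3 to compound 4 (0.03 log units; within the scatter). With phenyl held fixed, the pendant aryl ring also gains a second comparison, and cyano in place of trifluoromethyl gives a 1.3-fold higher number from compound 2 to compound 4 (0.10 log units; within the scatter), so these two groups cannot be told apart on this read-out. Cyano in place of fluoro amounts to an at least 1.9-fold lower number from compound 1 to compound 4 (0.28 log units; that floor lies within the scatter), which leaves that change unsettled, and its floor rests on the value of compound 1, which is a limit: the limit of > 10000 nM in this assay, at which 1 of the 4 values shown sits.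

As far as these compounds go, the finding on phenyl and methyl rests on a single pair, so it remains open whether a longer chain such as propyl, or an amine, would fare the same at that aromatic carbon. From the compounds shown here alone, it also remains open how a carboxylic acid or a methoxy group on the pendant aryl ring would compare with cyano and trifluoromethyl.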